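Removing a Ring Methyl in a Benzothiazole-Pyrimidine Series

The compounds below may be only part of what the source reports. "The series", "measured", "known", "first", "only" and "open" are said of these compounds alone.

Three compounds have been measured in a functional assay on PC-3 cells (Homo sapiens) for antiproliferative activity, read by MTT assay, with a stated time of 48 h; a lower number here means a stronger inhibitor, a higher number a weaker inhibitor:

compound 1, `Cc1ccc2nc(Nc3ccnc(Nc4ccc(S(C)(=O)=O)cc4)n3)sc2c1`, > 50000 nM
compound 2, `NS(=O)(=O)c1ccc(Nc2nccc(Nc3nc4ccc(F)cc4s3)n2)cc1`, 920 nM
compound 3, `Cc1ccc2nc(Nc3nc(Nc4ccc(S(N)(=O)=O)cc4)ncc3C)sc2c1`, 2710 nM

The value for compound 1 is a limit of this assay, not a number, as noted in the limit of > 50000 nM in this assay, at which 1 of the 3 values shown sits. Of the two numbers, compound 3 gives the higher one; compound 2 sits lower, and the gap between compound 2 and compound 3 lies beyond the usual scatter.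

Compound 4, `Cc1ccc2nc(Nc3ccnc(Nc4ccc(S(N)(=O)=O)cc4)n3)sc2c1`, has not yet been measured. It differs from compound 3 in one place: hydrogen in place of methyl on an aromatic carbon. Compound 4 shares with compound 2 the sulfonamide and the unsubstituted six-membered ring with two nitrogens, and with compound 3 the methyl on the fused ring system, so the number for compound 4 is expected to fall between those of compound 2 and compound 3 in this assay.

For compound 4 the estimate is 1300 nM, with a range of 400 nM to 4500 nM. This estimate means a step of a 2.1-fold lower number from compound 3 to compound 4 (0.32 log units; beyond the scatter), expected to be toward a lower number.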

Compound 4, half-maximal inhibitory concentration: 1640 nM
Estimate against measurement, compound 4: 1.3-fold (0.10 log units) below; the measured number falls inside the stated range.
By their numbers in this assay, from the lowest: compounds 2, 4 and 3 (each within the scatter of the next, the first and the last beyond it). At a limit, above all of these: compound 1.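

In this assay, the first single-place comparisons show that neither of two swaps on an aromatic carbon moves the number past the usual scatter: hydrogen in place of methyl on the six-membered ring with two nitrogens gives a 1.7-fold lower number from compound 3 to compound 4 (0.22 log units; within the scatter), and methyl in place of fluoro gives a 1.8-fold higher number from compound 2 to compound 4 (0.25 log units; within the scatter). Within the data shown here, the one large step lies at the sulfonyl sulfur, where amino in place of methyl gives an at least 30-fold lower number from compound 1 to compound 4 (1.48 log units; beyond the scatter). The value of compound 1 is a limit of the assay, not a number, so this step has no exact size: the limit of > 50000 nM in this assay, at which 1 of the 4 values shown sits.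

Open, going by these compounds, is how an amine, a methoxy group or a carboxylic acid would read on the aromatic carbon that carries methyl in compound 3. Also open, on these data alone, is how a dimethylamino group would read on the sulfonyl sulfur.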